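Ring swap on the shared core, compound 2 to compound 3

The source may report more compounds than this note shows. Statements on the series, on what has been measured and on what is new or still open speak of the compounds shown alone.

Compound 1 `S=c1[nH]nc(Cc2ccc(Cl)cc2Oc2ccccc2Cl)[nH]1` gives 139% in a functional assay on the whole organism (strain NMRI) with Mus musculus as the target, with a stated time of 60 min, at a dose of 10 mg/kg by the intraperitoneal route; on this read-out lower numbers stand for a weaker effect and higher numbers for a stronger effect at the one dose given. Going by the values given here, compound 2 `Nc1nnc(Cc2ccc(Cl)cc2Oc2ccccc2Cl)o1` gives 132% in this assay, the lower of the two numbers measured so far, with compound 1 nearest: a number 7 percentage points lower from compound 1 to compound 2 (within the scatter). Compound 3 `CCOc1nnc(Cc2ccc(Cl)cc2Oc2ccccc2Cl)[nH]1` has not yet been measured. It differs from compound 2 by a group of 8 heavy atoms (4 carbon, 3 nitrogen, 1 oxygen; one five-membered aromatic ring with 3 hetero atoms) in place of a group of 6 heavy atoms (2 carbon, 3 nitrogen, 1 oxygen; one five-membered aromatic ring with 3 hetero atoms), on a saturated chain carbon bound to an aromatic carbon. Among the compounds with values here, the one measured step at the saturated chain carbon bound to an aromatic carbon, a number 7 percentage points lower from compound 1 to compound 2 (within the scatter), stayed within the scatter, so a further exchange of the five-membered aromatic ring there is expected to move this assay by no more than the scatter. The expected step is a number 2 percentage points lower from compound 2 to compound 3 (within the scatter). Compound 3 is therefore estimated at 130%, within 110% to 150%.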

Compound 3, a percentage reported as activity, at one dose (the size of the read-out at that dose, not a potency): 122%
The estimate for compound 3 lay 8 percentage points above the measured number; measured number inside the range.
By their numbers in this assay, from the lowest: compounds 3, 2 and 1 (each within the scatter of the next, the first and the last beyond it).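

Within this assay, exchange of the group on the saturated chain carbon bound to an aromatic carbon now gives a number 17 percentage points lower from compound 1 to compound 3 (beyond the scatter) and thus the first step in the series beyond the scatter. The other new step is a number 10 percentage points lower from compound 2 to compound 3 (within the scatter) and does not separate that pair, so compound 2 cannot be placed apart from either neighbour. No measurement at hand accounts for either step.

Going by these compounds, whether a longer chain or a carboxylic acid on the five-membered aromatic ring would extend the step or reverse it remains open.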